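Replacing a Methylsulfonyl Group with a Cyclic Amine

A few compounds are considered here, and "the series" means these few. Any claim that something is new, unique, unknown or untested is made for them only; others in the source may bear on it.

Measured so far:
Compound 1 `CC(C)c1n[nH]c2c(NCc3ccc(-c4ccccn4)cc3)nc(S(C)(=O)=O)nc12` gives 640 nM in a functional assay on K562 cells (Homo sapiens) for cytotoxicity, read by fluorescence, with a stated time of 72 h; a lower number here means a stronger inhibitor, a higher number a weaker inhibitor.
Compound 2 `CC(C)c1n[nH]c2c(NCc3ccc(-c4ccccn4)cc3)nc(NCC(C)(C)O)nc12` gives 29 nM in this assay.

Compound 1 has the highest number of the two measured compounds. Within the data shown here, the one step known, a 22-fold lower number from compound 1 to compound 2 (1.34 log units; beyond the scatter), exchanges the methylsulfonyl group for an amine bearing a hydroxyl. Compound 3 `CC(C)c1n[nH]c2c(NCc3ccc(-c4ccccn4)cc3)nc(N3CCCCC3CCO)nc12` follows the same idea: 2-(2-hydroxyethyl)piperidin-1-yl in place of methylsulfonyl on an aromatic carbon. Since the entering group again carries a nitrogen and a hydroxyl, a large downward step is expected in this assay, close to the size of the step from compound 1 to compound 2, though the ring makes the parallel imperfect. For compound 3 the expected step is a 13-fold lower number from compound 1 to compound 3 (1.11 log units; beyond the scatter), giving an estimate of 50 nM, within 15 nM to 200 nM.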

Compound 3, half-maximal inhibitory concentration: 165 nM
Compound 3: the middle estimate sits 3.3-fold (0.52 log units) below what was measured, within the range that was stated.
By their numbers in this assay, from the lowest: compound 2; then compound 3; then compound 1.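

In this assay the gain at this aromatic carbon survives when the entering nitrogen sits in a six-membered ring, with a 3.9-fold lower number from compound 1 to compound 3 (0.59 log units; beyond the scatter) as the result. Much of the gain is lost against the open-chain group, however, with a 5.7-fold higher number from compound 2 to compound 3 (0.76 log units; beyond the scatter) marking the cost of this exchange. No measurement here accounts for that difference.

Still open, from the compounds shown here alone, is how much the hydroxyl itself contributes, and whether a plain piperidin-1-yl group, without the 2-hydroxyethyl chain, would lower the number as far.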